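This account rests on a few compounds, and the source may have more. Where it says the series, first, only, none or still open, it means among the compounds named here.

For the measured compounds named here, compound 1 `O=C(Nc1nc2ccccc2s1)c1cn(-c2ccccc2)nc1-c1ccccc1` gives 8960 nM in a functional assay on U-87MG ATCC cells for cytotoxicity against U-87 MG (Homo sapiens), read by MTT assay, with a stated time of 72 h (on this read-out higher numbers stand for weaker inhibition and lower numbers for stronger inhibition), and compound 2 `O=C(Nc1nc2ccccc2s1)c1cn(-c2ccccc2)nc1-c1ccc(Cl)cc1` gives 11500 nM, the highest of the two numbers so far; the step of a 1.3-fold higher number from compound 1 to compound 2 (0.11 log units; within the scatter) is within the scatter. Compound 3 `COc1ccc(-c2nn(-c3ccccc3)cc2C(=O)Nc2nc3ccccc3s2)cc1` carries the change (methoxy in place of chloro on an aromatic carbon), methoxy in place of chloro on an aromatic carbon. Going by the values given here, only the step from compound 1 to compound 2 bears on this position, and it was small; no change beyond the scatter is therefore expected, with a 1.2-fold lower number from compound 2 to compound 3 (0.06 log units; within the scatter) as the expected step. Compound 3 is estimated at 10000 nM, between 4000 nM and 30000 nM.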

Compound 3, half-maximal inhibitory concentration: 11500 nM
The estimate for compound 3 lay 1.2-fold (0.06 log units) below the measured number; the range from low to high includes it.
By their numbers in this assay, from the lowest: compounds 1, 2 and 3 (each within the scatter of the next).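

Methoxy in place of chloro gives no change at the digits printed from compound 2 to compound 3 (within the scatter), and methoxy in place of hydrogen gives a 1.3-fold higher number from compound 1 to compound 3 (0.11 log units; within the scatter). Hydrogen, chloro and methoxy, para to a large group, therefore all read within the scatter of one another, so adding a hydrogen-bond acceptor here, as methoxy does, leaves the number within that scatter. Nothing available explains this flat reading.

Going by these compounds, whether an amine, a carboxylic acid or a longer chain at this position would move the number beyond the scatter remains open. On these data alone, the effect of changes elsewhere on the shared core also remains open.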